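From 3,4-dichlorophenyl to thiophen-2-yl on a shared core

This account rests on a few compounds, and the source may have more. Where it says the series, first, only, none or still open, it means among the compounds named here.

Of the compounds shown here, three with one shared core have been measured in a functional assay on L1210 cells (Mus musculus) for antiproliferative activity; on this read-out higher numbers stand for weaker inhibition and lower numbers for stronger inhibition. Compound 1 `COc1ccc(-c2cc(N)c(C(=O)c3cc(OC)c(OC)c(OC)c3)s2)cc1OC`, which carries 3,4-dimethoxyphenyl, gives 40 nM. Compound 2 `COc1cc(C(=O)c2sc(-c3cccc([N+](=O)[O-])c3)cc2N)cc(OC)c1OC`, which carries 3-nitrophenyl, gives 11 nM. Compound 3 `COc1cc(C(=O)c2sc(-c3ccc(Cl)c(Cl)c3)cc2N)cc(OC)c1OC`, which carries 3,4-dichlorophenyl, gives 260 nM, the highest number of the three and so the weakest inhibition in this small set.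

The next compound, compound 4 `COc1cc(C(=O)c2sc(-c3cccs3)cc2N)cc(OC)c1OC`, has thiophen-2-yl in place of 3,4-dichlorophenyl on an aromatic carbon.

All three measured steps involve a change of group at this same place. They are a 3.6-fold lower number from compound 1 to compound 2 (0.56 log units; beyond the scatter), a 6.5-fold higher number from compound 1 to compound 3 (0.81 log units; beyond the scatter) and a 24-fold higher number from compound 2 to compound 3 (1.37 log units; beyond the scatter). The number in this assay has therefore moved by modest to large steps with the group at this place. Among the measured compounds shown here, no measured compound carries thiophen-2-yl, so the direction of the step cannot be read directly from the data. However, compound 3 sits at the top of the measured range, and both other groups give lower numbers, so a fall is more likely than a rise.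

The expected change is a 5.2-fold lower number from compound 3 to compound 4 (0.72 log units; beyond the scatter), a modest step towards stronger inhibition. For compound 4 the estimated value is 50 nM, with an expected range of 12 nM to 220 nM.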

Compound 4, half-maximal inhibitory concentration: 9.8 nM
For compound 4 the middle estimate is 5.1-fold (0.71 log units) above the measured one; the measured number lies below the stated range.
By their numbers in this assay, from the lowest: compounds 4 and 2 (each within the scatter of the next); then compound 1; then compound 3.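

With thiophen-2-yl, the place next to the ring sulfur is shown to accept a five-membered aromatic ring with a hetero atom, and in this assay this ring gives both a 27-fold lower number from compound 3 to compound 4 (1.42 log units; beyond the scatter) and a 4.1-fold lower number from compound 1 to compound 4 (0.61 log units; beyond the scatter), so a six-membered aromatic ring of carbon only is not needed here for the lower numbers. The remaining comparison is a 1.1-fold lower number from compound 2 to compound 4 (0.05 log units; within the scatter), which places thiophen-2-yl level with 3-nitrophenyl and shows that two quite different groups can reach the same low end of the range, while 3,4-dimethoxyphenyl and 3,4-dichlorophenyl stay clearly above it. Why these groups separate as they do cannot be said, since no independent data on the groups or on this change are available to account for it.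

From the compounds shown here alone, how furan-2-yl, thiophen-3-yl or an unsubstituted phenyl would compare at this place remains open, and so does the outcome with a non-aromatic group such as a piperidine or a short alkyl chain. Also open, going by these compounds, is whether the same order of groups would hold with a different group in place of the amino group on the shared core.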